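Methoxy on compound 1: a small step expected

The compounds below may be only part of what the source reports. "The series", "measured", "known", "first", "only" and "open" are said of these compounds alone.

Measured compounds:
compound 1 `O=[N+]([O-])c1cccc(-c2nn(-c3ccccc3)cc2C(Nc2nc3ccccc3s2)c2c(O)ccc3ccccc23)c1`: 43900 nM
compound 2 `O=[N+]([O-])c1ccc(-c2nn(-c3ccccc3)cc2C(Nc2nc3ccccc3s2)c2c(O)ccc3ccccc23)cc1`: 14700 nM
compound 3 `Cc1ccc(-c2nn(-c3ccccc3)cc2C(Nc2nc3ccccc3s2)c2c(O)ccc3ccccc23)cc1`: 13100 nM

In a functional assay on MCF7 cells (Homo sapiens) for antiproliferative activity, read by MTT assay, with a stated time of 48 h (a lower number here means a stronger inhibitor, a higher number a weaker inhibitor), compound 1 gives 43900 nM, the highest number of the three, which makes it the weakest inhibitor of this small set. Compound 4 `COc1ccc2nc(NC(c3cn(-c4ccccc4)nc3-c3cccc([N+](=O)[O-])c3)c3c(O)ccc4ccccc34)sc2c1` keeps the 3-nitrophenyl group of compound 1 and differs from it in one place: methoxy in place of hydrogen on an aromatic carbon. Methoxy stands in place of hydrogen on an aromatic carbon, so that 1,3-benzothiazol-2-yl becomes 6-methoxy-1,3-benzothiazol-2-yl.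

For the measured compounds named here, no measured step touches that place, so the evidence is only indirect. The nearest guide is how far the numbers moved when a different place changed. There were two modest steps, a 3.0-fold lower number from compound 1 to compound 2 (0.48 log units; beyond the scatter) and a 3.4-fold lower number from compound 1 to compound 3 (0.53 log units; beyond the scatter), while a 1.1-fold lower number from compound 2 to compound 3 (0.05 log units; within the scatter) stayed within the scatter. On that basis, no more than a modest step is expected, and quite possibly none beyond the scatter. A lower number seems somewhat likelier than a higher one, since compound 1 at 43900 nM already sits at the top of the measured values. The step expected is a 1.5-fold lower number from compound 1 to compound 4 (0.17 log units; within the scatter). For compound 4 the estimated value is 30000 nM, with an expected range from 11000 nM to 75000 nM.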

Compound 4, half-maximal inhibitory concentration: 26800 nM
Estimate against measurement, compound 4: 1.1-fold (0.05 log units) above, and the stated range covers the measured number.
By their numbers in this assay, from the lowest: compounds 3, 2, 4 and 1 (each within the scatter of the next, the first and the last beyond it).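

In this assay, the change of 1,3-benzothiazol-2-yl to 6-methoxy-1,3-benzothiazol-2-yl gives a 1.6-fold lower number from compound 1 to compound 4 (0.21 log units; within the scatter), so this aromatic carbon carries a methoxy group in compound 4 with no step beyond the scatter. For the compounds shown here, compounds 1, 2 and 3 share the unsubstituted 1,3-benzothiazol-2-yl group and differ only in the substituted phenyl group, so they could say nothing about this place; compound 4 gives the first reading of it, and on the parent with 3-nitrophenyl that reading is a small one. Nothing available explains the size of this step or links it to any property of the methoxy group.

Going by these compounds, whether this position stays as undemanding with other groups, such as a hydroxyl, a chlorine atom, an amine or a carboxylic acid, remains open. Also open, on these data alone, is whether methoxy at this position would give a similarly small step alongside the 4-nitrophenyl group of compound 2 or the 4-methylphenyl group of compound 3, since a single pair cannot show how the two places combine.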